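The source may hold more compounds than are shown below. What is called first, only, known or untested is meant among the compounds shown, and "the series" means these compounds.

Values in an ADME assay on MRC5 cells (Homo sapiens) for cytotoxicity, read by fluorescence, with a stated time of 24 h (a lower number here means a stronger inhibitor, a higher number a weaker inhibitor), so far

- compound 1 `Nc1ccccc1C(=O)N/N=C/c1ccc2no[n+]([O-])c2c1` gives 122000 nM
- compound 2 `N#Cc1c(-c2ccco2)[n+]([O-])c2ccc(C3OCCO3)cc2[n+]1[O-]` gives 35700 nM
- compound 3 `NC(=O)c1c(COc2cccc(/C=N/NC(=O)c3ccncc3)c2)no[n+]1[O-]` gives 1280000 nM

Compound 1 (122000 nM) holds the second highest of the three numbers, with compound 2 lower and compound 3 higher, each gap beyond the scatter. Compound 4 `Nc1ccc(C(=O)N/N=C/c2ccc3no[n+]([O-])c3c2)cc1` keeps the core of compound 1 and has the same atoms joined differently, with 4-aminophenyl in place of 2-aminophenyl on a carbonyl carbon. For the measured compounds named here, no two measured compounds differ in one place only, so the data give no direct guide to the size of this step. In this assay no change beyond the scatter is expected, and no direction is favoured with any confidence. The estimated step is small (a 1.2-fold lower number from compound 1 to compound 4 (0.09 log units; within the scatter)). The measured values run from compound 2 (35700 nM) to compound 3 (1280000 nM), and the range is kept wide accordingly. Compound 4 is expected at 100000 nM (estimated range 35000 nM to 300000 nM).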

Compound 4, half-maximal inhibitory concentration in the MRC5 assay: 841000 nM
Estimate against measurement, compound 4: 8.4-fold (0.92 log units) below; measured number above the stated range.
By their numbers in the MRC5 assay, from the lowest: compound 2; then compound 1; then compounds 4 and 3 (each within the scatter of the next).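

In the MRC5 assay, 4-aminophenyl in place of 2-aminophenyl on a carbonyl carbon is not a neutral exchange: with the same atoms joined differently, the change gives a 6.9-fold higher number from compound 1 to compound 4 (0.84 log units; beyond the scatter). For the compounds shown here, this is the only one-place step so far, and it shows that the arrangement of the aminophenyl group on this carbonyl carbon matters for this read-out, even with the core of compound 1 kept. The same change also shifts lipophilicity in a physicochemical assay for lipophilicity, read by HPLC, measured as octanol-water partition; on this read-out lower numbers stand for lower lipophilicity and higher numbers for higher lipophilicity: the measured partition coefficient of compound 1, 2, and of compound 4, 1.2, a number 0.80 log units lower (beyond the scatter) In the physicochemical assay compound 1 gives 2 and compound 4 gives 1.2.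

A single pair cannot show whether the shifts in these two read-outs are connected. 3-Aminophenyl or 4-carboxyphenyl on the same carbonyl carbon would test whether the number in the MRC5 assay follows the partition coefficient or depends on the particular group.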